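N-Methylation of a Bridged Amine and Maximal Response

The source may hold more compounds than are shown below. What is called first, only, known or untested is meant among the compounds shown, and "the series" means these compounds.

Measured compounds:
- compound 1 `C1=C(c2cccnc2)C[C@@H]2CNC[C@H]1C2`: in a functional assay on synaptosomes from brain (strain Sprague-Dawley) for agonist activity at Nicotinic acetylcholine receptor alpha6/alpha3/beta2/beta3 (Rattus norvegicus) (on this read-out lower numbers stand for smaller maximal responses and higher numbers for larger maximal responses), compound 1 reaches 49%
- compound 2 `CN1C[C@@H]2C=C(c3cccnc3)C[C@@H](C2)C1`: in this assay compound 2 reaches 13%
- compound 3 `CC(C)Oc1cncc(C2=CC3CNCC(C2)C3)c1`: in this assay compound 3 reaches 86%

Compound 3 stands highest of the three in this assay, and its gaps to compound 1 and compound 2 both lie beyond the usual scatter. Compound 1 and compound 2 share one core; compound 2 carries the change (methyl in place of hydrogen on an amine nitrogen in a ring), and this brought a number 36 percentage points lower from compound 1 to compound 2 (beyond the scatter). Compound 3 and compound 1 differ in more than one place, so the difference between the two cores is not broken down here.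

Compound 4 `CC(C)Oc1cncc(C2=CC3CC(C2)CN(C)C3)c1` has not yet been measured. It relates to compound 3 exactly as compound 2 relates to compound 1: the change is methyl in place of hydrogen on an amine nitrogen in a ring, the same change at the same kind of place. Because a number 36 percentage points lower from compound 1 to compound 2 (beyond the scatter) was large, a drop of similar size is expected in this assay, giving an estimated a number 41 percentage points lower from compound 3 to compound 4 (beyond the scatter). On this basis compound 4 is estimated at 45%, likely between 22% and 70%, with the wider range reflecting that the step was seen only once and on a different core.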

Compound 4, largest response reached (reported as percent of maximum), in percent of the reference or control that the assay uses: 63%
Compound 4: the middle estimate sits 18 percentage points below what was measured; measured number inside the range.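

On the second core, in this assay, methyl in place of hydrogen on an amine nitrogen in a ring again lowers the maximal response, giving a number 23 percentage points lower from compound 3 to compound 4 (beyond the scatter) in a step of modest size. Set beside the earlier step, this one points the same way, and the two cannot be told apart in size: the same change on two cores in this assay, a number 36 percentage points lower (beyond the scatter) from compound 1 to compound 2 and a number 23 percentage points lower (beyond the scatter) from compound 3 to compound 4, 13 percentage points apart, within the scatter of two such steps. This shows that the change carried over between these two cores in direction and, within the scatter, in size, but two pairs do not show that it would do so on every core in the series, and they do not explain why the response falls.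

The compounds shown carry only hydrogen or methyl on that nitrogen, which leaves open what ethyl, a longer chain or an acetyl group would do there. Also open, from the compounds shown here alone, is whether the step holds on a third core, for instance one carrying an amine or a fluorine atom where compound 3 has its isopropoxy group.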